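This account rests on a few compounds, and the source may have more. Where it says the series, first, only, none or still open, it means among the compounds named here.

In an ADME assay on HFF cells (Homo sapiens) for cytotoxicity, with a stated time of 8 days (on this read-out lower numbers stand for higher toxicity in this test and higher numbers for lower toxicity in this test), compound 1 (`CCCSc1nc(N)nc2c1ncn2/C=C1/CC1(CO)CO`) gives > 300000 nM as a limit of the assay, not a number. Compound 2 (`CC(C)Nc1nc(N)nc2c1ncn2/C=C1/CC1(CO)CO`) gives > 300000 nM as a limit too. Compound 3 (`Nc1nc(NC2CC2)c2ncn(/C=C3/CC3(CO)CO)c2n1`) gives > 300000 nM as a limit as well. The whole record so far is the limit of > 300000 nM in this assay, at which 3 of the 3 values shown sit, and nothing finer. Compound 4 (`Nc1nc(NC2CCCCC2)c2ncn(/C=C3/CC3(CO)CO)c2n1`) has cyclohexyl in place of cyclopropyl on a nitrogen on an aromatic ring. The nearest measured change is a step that the two limits leave unreadable from compound 2 to compound 3 and the changes a step that the two limits leave unreadable from compound 1 to compound 2 and a step that the two limits leave unreadable from compound 1 to compound 3 likewise give no size, so none of them points to a step beyond the scatter. At most a small move toward lower numbers is expected, estimated as an at least 1.5-fold lower number from compound 3 to compound 4 (0.17 log units; that floor lies within the scatter) in this case. For compound 4 the expected value is 200000 nM with an estimated range of 60000 nM to 400000 nM and the assay may well report only a limit again.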

Compound 4, half-maximal cytotoxic concentration: > 300000 nM
Compound 4 was reported as a limit; the forecaster's own chance of this, stated with the estimate: 65%; middle value at least 1.5-fold (0.17 log units) away from the limit.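

Compound 4 also gives only a limit of the assay, so no step among compound 1, compound 2, compound 3 and compound 4 can be read: the limit of > 300000 nM in this assay, at which 4 of the 4 values shown sit.

Going by these compounds, how these four compounds truly compare in this assay stays open, as does which change, if any, would give a readable number.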